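From 3-fluorophenyl to 4-methoxyphenyl at the assay limit

The compounds below may be only part of what the source reports. "The series", "measured", "known", "first", "only" and "open" are said of these compounds alone.

Compound 1 `COc1cc(-c2ncnn2-c2cccc(F)c2)cc(OC)c1OC` is the starting point here. In a functional assay on HL-60 cells (Homo sapiens) for antiproliferative activity, read by MTT assay, with a stated time of 72 h (on this read-out lower numbers stand for stronger inhibition and higher numbers for weaker inhibition), compound 1 gives > 10000 nM as a limit of the assay and not as a number. Compound 2 `COc1cccc(-c2ncnn2-c2cc(OC)c(OC)c(OC)c2)c1` gives > 10000 nM as a limit too. Compound 3 `COc1cc(-n2ncnc2-c2ccccc2)cc(OC)c1OC` likewise gives > 10000 nM as a limit. The whole set rests on the limit of > 10000 nM in this assay, at which 3 of the 3 values shown sit, and so offers no ranking, and compound 1 stands level with the other two as far as can be told.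

Compound 4 `COc1ccc(-n2ncnc2-c2cc(OC)c(OC)c(OC)c2)cc1` keeps the core of compound 1 but carries 4-methoxyphenyl in place of 3-fluorophenyl on an aromatic nitrogen. Counted out, the exchange is 4-methoxyphenyl in place of 3-fluorophenyl on an aromatic nitrogen and no measured compound tests it. For the measured compounds named here, the only measured step is a step that the two limits leave unreadable from compound 2 to compound 3 and it concerns a different change, so it sets no size for this one. Any readable value for compound 4 would mean a move toward stronger inhibition in this assay but staying at the limit remains a real possibility. The expected change, a rough estimate only, is an at least 3.3-fold lower number from compound 1 to compound 4 (0.52 log units; beyond the scatter) and it carries wide uncertainty. Compound 4 is estimated at 3000 nM with an expected range from 100 nM to 20000 nM as its bounds.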

Compound 4, half-maximal inhibitory concentration: 6200 nM
Compound 4: the middle estimate sits 2.1-fold (0.32 log units) below what was measured; measured number inside the range.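

In this assay, for the compounds shown here, compound 4 gives 6200 nM, the first readable number in this set, so the aromatic nitrogen of the shared core can carry a group that brings the result within reach of the assay. Exchanging 3-fluorophenyl for 4-methoxyphenyl at this position gives an at least 1.6-fold lower number from compound 1 to compound 4 (0.20 log units; that floor lies within the scatter), which shows the direction of the change but fixes only its smallest possible size, and that smallest size alone does not establish a real difference. The true size stays unknown because compound 1 offers only a limit and no number, and the same problem runs through the set: the limit of > 10000 nM in this assay, at which 3 of the 4 values shown sit.

The compounds shown leave open whether the methoxy group itself or its place in 4-methoxyphenyl matters more, a question that 4-fluorophenyl or 3-methoxyphenyl on the same nitrogen would help to settle. Also open, as far as these compounds go, is how a phenyl ring carrying a different kind of group at this position, such as an amine or a carboxylic acid, would read in this assay.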